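Swapping One Phenyl Group on a Shared Core

The source may report more compounds than this note shows. Statements on the series, on what has been measured and on what is new or still open speak of the compounds shown alone.

Compound 1, `C=CCn1c(=O)/c(=C\c2cccc(Cl)c2)[nH]c(=O)/c1=C\c1ccccc1OC`: 8900 nM
Compound 2, `C=CCn1c(=O)/c(=C\c2cccc(Br)c2)[nH]c(=O)/c1=C\c1ccccc1OC`: 2300 nM

Both were tested in a functional assay on Huh-7 cells (Homo sapiens) for cytotoxicity, read by CCK-8 assay, with a stated time of 72 h; on this read-out higher numbers stand for weaker inhibition and lower numbers for stronger inhibition. Going by the values given here, compound 2 gives the lowest number of the two, and the only step measured so far is a 3.9-fold lower number from compound 1 to compound 2 (0.59 log units; beyond the scatter). Compound 3, `C=CCn1c(=O)/c(=C\c2ccccc2C(F)(F)F)[nH]c(=O)/c1=C\c1ccccc1OC`, differs from compound 2 by 2-(trifluoromethyl)phenyl in place of 3-bromophenyl on a double-bonded chain carbon bound to an aromatic carbon. Among the compounds with values here, no measured step covers this change; the chloro-to-bromo step is the only guide, and it concerns a different substituent on the ring. The outcome is therefore uncertain, and a step of about a 2.2-fold higher number from compound 2 to compound 3 (0.34 log units; beyond the scatter) is expected. Compound 3 is estimated to give 5000 nM, between 1500 nM and 17000 nM.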

Compound 3, half-maximal inhibitory concentration: 9500 nM
Compound 3: middle estimate off by 1.9-fold (0.28 log units), on the low side, and the stated range covers the measured number.
By their numbers in this assay, from the lowest: compound 2; then compounds 1 and 3 (each within the scatter of the next).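

In this assay the step of a 4.1-fold higher number from compound 2 to compound 3 (0.62 log units; beyond the scatter) shows that this position does not tolerate every change of its aromatic group equally. The step of a 1.1-fold higher number from compound 1 to compound 3 (0.03 log units; within the scatter) lies within the scatter, so 2-(trifluoromethyl)phenyl and 3-chlorophenyl cannot be told apart here, and only the 3-bromophenyl of compound 2 stands out. No measurement at hand explains this difference.

These three compounds cannot separate the effect of the substituent from that of its place on the ring, which 2-bromophenyl or 3-(trifluoromethyl)phenyl could address. As far as these compounds go, how a ring bearing an amine or a carboxylic acid would read also remains open.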